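A Methyl Added to the Phenyl of Compound 2

The source may hold more compounds than are shown below. What is called first, only, known or untested is meant among the compounds shown, and "the series" means these compounds.

Measured so far:
compound 1, `O=[N+]([O-])c1cccc(-n2cc(COc3ccc4c(c3)CCC4)nn2)c1` — "not determined" (no result reported) in an ADME assay on HEK293 cells (Homo sapiens) for inhibition, read by MTT assay, with a stated time of 48 h, tested at 25 uM; on this read-out lower numbers stand for less inhibition and higher numbers for more inhibition at the one concentration tested (going by the name of the read-out)
compound 2, `c1ccc(-n2cc(COc3ccc4c(c3)CCC4)nn2)cc1` — 23.4%

Among the compounds with values here, compound 2 stands alone on the numbers: in this assay compound 2 gives the only value shown, 23.4%, while compound 1 has no result at all. Compound 3, `Cc1cccc(-n2cc(COc3ccc4c(c3)CCC4)nn2)c1`, differs from compound 2 by methyl in place of hydrogen on an aromatic carbon, turning the phenyl into a 3-methylphenyl. Within the data shown here, no step between measured compounds exists here, so nothing tells how this assay answers such a change; a shift no larger than the usual scatter, in either direction, is expected. Compound 3 is therefore expected to give about 27%, somewhere between 10% and 45%, an expected step of a number 3.6 percentage points higher from compound 2 to compound 3 (within the scatter).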

Compound 3, a percentage reported as inhibition, at one concentration (the size of the read-out at that concentration, not a potency): 23.4%
The estimate for compound 3 lay 3.6 percentage points above the measured number, within the range that was stated.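

Placing a methyl on the phenyl, meta to a large group, gives no change at the digits printed from compound 2 to compound 3 (within the scatter) in this assay, the only step in this series that can be read. The phenyl of compound 2 therefore takes a methyl at this place with no shift beyond the usual scatter at the one concentration tested. No other measurement bears on this result. As far as these compounds go, whether an amine, a carboxylic acid or a longer chain at this place would behave the same stays open. Compound 1 has no number, so its nitro group offers no comparison.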